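The source may hold more compounds than are shown below. What is called first, only, known or untested is meant among the compounds shown, and "the series" means these compounds.

Measured in a functional assay on A549 cells (Homo sapiens) for inhibition, read by sulforhodamine B assay, with a stated time of 72 h; a higher number here means a weaker inhibitor, a lower number a stronger inhibitor:
compound 1 `Nc1sc(-c2ccc(Cl)cc2)c(-c2ccc(Cl)cc2)c1C(=O)NC1CCC(O)CC1` gives 250 nM;
compound 2 `CC(C)CNC(=O)c1c(N)sc(-c2ccc(Cl)cc2)c1-c1ccc(Cl)cc1` gives 21000 nM;
compound 3 `Nc1sc(-c2ccc(Cl)cc2)c(-c2ccc(Cl)cc2)c1C(=O)Nc1ccccc1` gives 25000 nM.

Compound 1 has the lowest number of the three, and both other compounds lie beyond the scatter from it. Replacing the 4-hydroxycyclohexyl group gave an 84-fold higher number from compound 1 to compound 2 (1.92 log units; beyond the scatter) and a 100-fold higher number from compound 1 to compound 3 (2.00 log units; beyond the scatter), while between the two replacements there was only a 1.2-fold higher number from compound 2 to compound 3 (0.08 log units; within the scatter).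

Compound 4 `CCCCNC(=O)c1c(N)sc(-c2ccc(Cl)cc2)c1-c1ccc(Cl)cc1` differs from compound 1 by butyl in place of 4-hydroxycyclohexyl on an amide-type nitrogen. Among the measured compounds shown here, the closest precedent is the step to compound 2, where an isobutyl group on the same nitrogen gave an 84-fold higher number from compound 1 to compound 2 (1.92 log units; beyond the scatter); the step to compound 3 was of the same size. Both measured replacements of the 4-hydroxycyclohexyl group raised the number by a large margin, so a large rise is expected for compound 4 as well, estimated as an 80-fold higher number from compound 1 to compound 4 (1.90 log units; beyond the scatter). Compound 4 is therefore expected at 20000 nM, within 6000 nM to 60000 nM.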

Compound 4, half-maximal inhibitory concentration: 8170 nM
Beside the measured number, compound 4's estimate is 2.4-fold (0.39 log units) above it, within the range that was stated.
By their numbers in this assay, from the lowest: compound 1; then compound 4; then compounds 2 and 3 (each within the scatter of the next).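

Among the chains on the amide-type nitrogen, butyl separates from both earlier replacements, with a 2.6-fold lower number from compound 2 to compound 4 (0.41 log units; beyond the scatter) and a 3.1-fold lower number from compound 3 to compound 4 (0.49 log units; beyond the scatter), so this position still responds to changes that lack the 4-hydroxycyclohexyl group. That response is small beside the remaining gap of a 33-fold higher number from compound 1 to compound 4 (1.51 log units; beyond the scatter), and none of compounds 2, 3 and 4 comes near compound 1. No supporting data explain these differences.

From the compounds shown here alone, whether the hydroxyl or the ring matters more remains open. Plain cyclohexyl and 4-hydroxybutyl on the same nitrogen would separate the two.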